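The source may hold more compounds than are shown below. What is called first, only, known or untested is meant among the compounds shown, and "the series" means these compounds.

Compounds measured so far in a functional assay on the whole organism for inhibition, with Rattus norvegicus as the target; on this read-out higher numbers stand for an effect only at larger amounts of compound and lower numbers for an effect already at smaller amounts:

Compound 1 `CC1CC/C(=N\Nc2ccccc2)c2ncc(C#N)c(=O)n21` gives > 1000 umol/kg in this assay, a limit of the assay rather than a number.
Compound 2 `CC1CC/C(=N\Nc2ccccc2Cl)c2ncc(C(=O)O)c(=O)n21` gives > 1000 umol/kg in this assay, again a limit.
Compound 3 `C[C@H]1CC/C(=N\Nc2ccc(O)cc2)c2ncc(C(=O)O)c(=O)n21` gives > 100 umol/kg in this assay, also a limit.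

Compound 2 stands at the limit of > 1000 umol/kg in this assay, at which 2 of the 3 values shown sit, the same limit as compound 1, while compound 3 sits at the limit of > 100 umol/kg in this assay, at which 1 of the 3 values shown sits. Among the compounds with values here, no value shown is an actual number, so no step between measured compounds can be sized.

Compound 4 `Cc1cccc(N/N=C2\CCC(C)n3c2ncc(C(=O)O)c3=O)c1` differs from compound 2 by 3-methylphenyl in place of 2-chlorophenyl on an amine nitrogen. Within the data shown here, with only limits on record, no direction for the step is supported, and a change beyond the scatter cannot be argued from the data; compound 4 is expected to land near the same limit, with the step from compound 2 to compound 4 estimated as a number no higher from compound 2 to compound 4 (the limit leaves the size open). For compound 4 the estimate in this assay is 1000 umol/kg, within the range 300 umol/kg to 3000 umol/kg.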

Compound 4, dose for 50% inhibition: 72.5 umol/kg
Beside the measured number, compound 4's estimate is 14-fold (1.14 log units) above it, and the stated range ends above it.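

In this assay, within the data shown here, 3-methylphenyl in place of 2-chlorophenyl on an amine nitrogen gives an at least 13-fold lower number from compound 2 to compound 4 (1.13 log units; beyond the scatter), the first step that can be sized. The aryl group at this place therefore changes the read-out, with the rest of the core unchanged. Compound 2 remains a limit of the assay and not a number: the limit of > 1000 umol/kg in this assay, at which 2 of the 4 values shown sit.

As far as these compounds go, whether the step follows from losing the chlorine or gaining the methyl stays open. 3-Chlorophenyl and 2-methylphenyl on the same core would separate group from ring position.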